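The compounds below may be only part of what the source reports. "The series", "measured", "known", "first", "only" and "open" are said of these compounds alone.

Measured compounds:
Compound 1 `O=c1c2cnn(-c3ccc(F)cc3)c2ncn1CC1(O)CCN(Cc2ccc(Br)cc2)CC1`: 6700 nM
Compound 2 `O=c1c2cnn(-c3ccc(F)cc3)c2ncn1CC1(O)CCN(Cc2cc(F)cc(F)c2)CC1`: "not determined" (no result reported)

In an assay on Sf21 cells for inhibition of ubiquitin carboxyl-terminal hydrolase 7 (Homo sapiens), read by spectrophotometry, with stated times of 30 min and 2 h (on this read-out higher numbers stand for weaker inhibition and lower numbers for stronger inhibition), compound 1 gives 6700 nM. Compound 2 shares the core of compound 1 and carries a 3,5-difluorobenzyl group on the saturated chain carbon bound to the amine nitrogen in the ring. In this assay compound 2 gives "not determined" (no result reported), so compound 2 stands without a number of its own and offers no point of comparison with compound 1.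

Compound 3 `COC(=O)c1ccc(CN2CCC(O)(Cn3cnc4c(cnn4-c4ccc(F)cc4)c3=O)CC2)c(Br)c1` is not yet measured. It differs from compound 2 in one place: 2-bromo-4-(methoxycarbonyl)phenyl in place of 3,5-difluorophenyl on a saturated chain carbon bound to an amine nitrogen in a ring. The 2-bromo-4-(methoxycarbonyl)phenyl group that enters carries a bromine, as does the benzyl group of compound 1, and the only measured anchor for the series is compound 1 in this assay. For the measured compounds named here, because compound 2 has no value, no step can be given; the expectation is only that compound 3 lands in the same weak region as compound 1, with no direction beyond the scatter claimed. Compound 3 is estimated at 5000 nM in this assay, within a range of 1500 nM to 20000 nM.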

Compound 3, half-maximal inhibitory concentration: 900 nM
Beside the measured number, compound 3's estimate is 5.6-fold (0.74 log units) above it; the whole stated range lies above it.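

In this assay, the group on the saturated chain carbon bound to an amine nitrogen in a ring now shows that it can move the read-out: 2-bromo-4-(methoxycarbonyl)phenyl in place of 4-bromophenyl gives a 7.4-fold lower number from compound 1 to compound 3 (0.87 log units; beyond the scatter), a step beyond the usual scatter. For the compounds shown here, this is the only step that can be read at this position, since the change from compound 2 to compound 3 has no number at its starting point, and it shows that a bromine-bearing benzyl group does not fix the series at the weak level of compound 1. No measurement at hand accounts for the step.

The change alters two things at once, adding the methoxycarbonyl group and giving the bromine a different printed place, so the compounds shown leave open which of them carries the step. On these data alone, it also remains open whether a 4-(methoxycarbonyl)phenyl group without bromine would keep compound 3's 900 nM in this assay, and whether a carboxylic acid or a primary amide in place of the methyl ester would do the same.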